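This account rests on a few compounds, and the source may have more. Where it says the series, first, only, none or still open, it means among the compounds named here.

Among the measured compounds shown here, compound 2 `Cc1ccccc1-c1nnc(NNC(C)C)s1` gives in a functional assay on the whole organism with Mus musculus as the target, in the maximal electroshock model, with a stated time of 1 h (a higher number here means that more compound is needed for the effect, a lower number that less compound is needed), a value of 83 mg/kg, the only full number among the three compounds tested so far. Compound 1 `NN(c1ccccc1)c1nnc(-c2ccccc2-c2ccccc2)s1` gives in this assay only a limit of the assay, > 100 mg/kg. Compound 3 `Cc1ccccc1-c1nnc(NNC2CCCC2)s1` likewise gives only a limit, > 100 mg/kg. For the measured compounds named here, the only measured step, an at least 1.2-fold higher number from compound 2 to compound 3 (0.08 log units; that floor lies within the scatter), alters the amine nitrogen rather than the aromatic carbon, so it offers little guidance here. Compound 4 `CC(C)NNc1nnc(-c2ccccc2-c2ccccc2)s1` differs from compound 2 by phenyl in place of methyl on an aromatic carbon. Compound 1 carries that same phenyl group, and its result sits at the limit of > 100 mg/kg in this assay, at which 2 of the 3 values shown sit. The number for compound 4 is therefore expected to move upward, a 1.8-fold higher number from compound 2 to compound 4 (0.26 log units; within the scatter), with a real chance that only a limit is reported. Compound 4 is estimated at 150 mg/kg, between 70 mg/kg and 400 mg/kg.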

Compound 4, dose for half-maximal effect: 35 mg/kg
Compound 4: middle estimate off by 4.3-fold (0.63 log units), on the high side, and the stated range ends above it.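

In this assay, the aromatic carbon ortho to a large group accepts phenyl in place of methyl, and less compound is needed: a 2.4-fold lower number from compound 2 to compound 4 (0.38 log units; beyond the scatter). Phenyl here therefore does not by itself push the number up, since with phenyl kept, changing the group on the other end of the core gives an at least 2.8-fold lower number from compound 1 to compound 4 (0.45 log units; beyond the scatter). Compound 1 stands at a limit, not a number: the limit of > 100 mg/kg in this assay, at which 2 of the 4 values shown sit.

From the compounds shown here alone, whether a smaller group such as chlorine or methoxy on that carbon would serve as well stays open. So does whether phenyl gives the same lower number when cyclopentyl sits on the amine nitrogen.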